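The compounds below may be only part of what the source reports. "The series", "measured", "known", "first", "only" and "open" are said of these compounds alone.

Measured so far:
compound 1 `Clc1cc(Cl)cc(CO[C@H]2CCCN(Cc3cccnc3)[C@H]2c2ccccc2)c1` — 112000 nM
compound 2 `O=C(O)c1ccc2c(CN3CCC[C@H](O[C@H](CO)c4cc(Cl)cc(Cl)c4)[C@@H]3c3ccccc3)c[nH]c2c1` — 22000 nM

Two compounds share a core built around a saturated ring with an amine nitrogen and carry a dichlorophenyl group on one side. Both were tested in an assay on isolated protein for activation of cGMP-dependent protein kinase 1 (Homo sapiens), read by ADP-Glo, with stated times of 120 min and 40 min; on this read-out lower numbers stand for an effect already at smaller amounts and higher numbers for an effect only at larger amounts of compound. Compound 1 gives 112000 nM, the highest number of the two. Compound 2, whose structure is `O=C(O)c1ccc2c(CN3CCC[C@H](O[C@H](CO)c4cc(Cl)cc(Cl)c4)[C@@H]3c3ccccc3)c[nH]c2c1`, gives 22000 nM, a lower number, and the gap between the two lies beyond the usual scatter of the measurement.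

Compound 3 `CN1CCC[C@H](OCc2cc(Cl)cc(Cl)c2)[C@@H]1c1ccccc1` has not yet been tested. It differs from compound 1 in one place: hydrogen in place of pyridin-3-yl on a saturated chain carbon bound to an amine nitrogen in a ring. The group attached to the amine nitrogen thus shrinks from a larger aromatic-bearing piece to the smallest possible one. Among the compounds with values here, with only two measured compounds, no step between them can be attributed to this kind of change. Within the data shown here, still, the one comparison available shows that a larger group at this position goes with a lower number, as compound 2 does relative to compound 1.

For compound 3 a step in the other direction, towards a higher number, is therefore expected, of moderate size, a 2.0-fold higher number from compound 1 to compound 3 (0.29 log units; within the scatter). Compound 3 is estimated to give about 220000 nM, with a plausible range from 80000 nM to 600000 nM.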

Compound 3, half-maximal effective concentration: > 200000 nM
Compound 3 gave a limit, no number; the forecaster's own chance of this, stated with the estimate: 40%; the middle value lies beyond the limit too.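

In this assay compound 3 gives > 200000 nM, which is a limit of the assay and not a number. Within the data shown here, this provides the first comparison that changes only one place: with hydrogen in place of pyridin-3-yl on a saturated chain carbon bound to an amine nitrogen in a ring, so that (pyridin-3-yl)methyl becomes methyl, the result is an at least 1.7-fold higher number from compound 1 to compound 3 (0.25 log units; that floor lies within the scatter). The change therefore gives no sign of a lower number, but the true size of the step stays unknown, and the printed floor alone does not show a change beyond the usual scatter, because compound 3 reaches the end of the measurable range: the limit of > 200000 nM in this assay, at which 1 of the 3 values shown sits.

From the compounds shown here alone, whether a group of intermediate size on the amine nitrogen, such as ethyl or a longer propyl chain, would give a readable number remains open, and so does whether benzyl, which has a plain phenyl ring in place of pyridin-3-yl, would match compound 1. Compound 2 differs from compound 1 in more than one place, so it cannot show how much of its lower number comes from the group on this nitrogen.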